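A Fluorine Step Repeated on a Rearranged Core

The source may hold more compounds than are shown below. What is called first, only, known or untested is meant among the compounds shown, and "the series" means these compounds.

The set begins with compound 1, `Fc1ccc2nc(-c3cc(-c4ccccc4)n(-c4ccccc4)n3)ccc2c1`, and compound 3, `Fc1ccc2nc(-c3cc(-c4ccccc4)nn3-c3ccccc3)ccc2c1`, which are built from the same atoms joined differently; the difference between the two cores is not broken down here. In an ADME assay on Huh-7 cells (Homo sapiens) for cytotoxicity, read by XTT assay, with a stated time of 3 days, tested at 20 uM (on this read-out higher numbers stand for a weaker effect at the one concentration tested and lower numbers for a stronger effect), compound 1 gives 124%, and compound 3 gives 126%, two numbers that lie within the usual scatter of each other. Compound 2, `Fc1ccc(-c2cc(-c3ccc4cc(F)ccc4n3)nn2-c2ccccc2)cc1`, differs from compound 1 by fluoro in place of hydrogen on an aromatic carbon. In this assay, among the compounds with values here, compound 2 gives 88.3%, the lowest number among the three measured compounds, and the only step here that exceeds the scatter.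

Compound 4, `Fc1ccc(-n2nc(-c3ccccc3)cc2-c2ccc3cc(F)ccc3n2)cc1`, is not yet measured in this assay. It differs from compound 3 by fluoro in place of hydrogen on an aromatic carbon, and the place of the change is described in the same words as for the change from compound 1 to compound 2, so the same change is carried onto the other core. Because a number 35.7 percentage points lower from compound 1 to compound 2 (beyond the scatter), compound 4 is expected to show a step of similar direction, a number 33 percentage points lower from compound 3 to compound 4 (beyond the scatter), though a single measured instance on a different core leaves the size uncertain. Compound 4 is therefore estimated at 93% in this assay, with a range from 65% to 125%.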

Compound 4, a percentage reported as activity, at one concentration (the size of the read-out at that concentration, not a potency): 97.8%
Beside the measured number, compound 4's estimate is 4.8 percentage points below it; low and high end bracket the measured number.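

In this assay, the change from phenyl to 4-fluorophenyl on the rearranged core gives a number 28.2 percentage points lower from compound 3 to compound 4 (beyond the scatter), so the number falls on this core as it did on the first. The two steps agree in direction and do not differ in size beyond what repeated measurements of this kind allow: the same change on two cores in this assay, a number 35.7 percentage points lower (beyond the scatter) from compound 1 to compound 2 and a number 28.2 percentage points lower (beyond the scatter) from compound 3 to compound 4, 7.5 percentage points apart, within the scatter of two such steps. This shows that the change carried from one core to the other in this series, but it rests on one pair per core at a single concentration, and it does not show why the number falls or that the step would hold on any further core.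

The compounds shown carry only hydrogen or fluoro at the changed place, so it remains open whether chloro, methoxy, an amine or a carboxylic acid there would move the number in the same direction or by a similar amount. It also remains open what a second fluoro on the same compound would do, since neither core is shown with more than the one added fluoro on its phenyl groups.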